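The compounds below may be only part of what the source reports. "The series", "measured", "known", "first", "only" and "open" are said of these compounds alone.

In a physicochemical assay for solubility, in phosphate buffer, with a stated time of 18 h (on this read-out higher numbers stand for higher solubility and lower numbers for lower solubility), compound 1 `CCCCc1nc(C(C)(C)C)nc2nc(N)c(C#N)c(N)c12` gives 6000 nM. Compound 2 `CC(C)(C)c1nc(C2CCCC2)c2c(N)c(C#N)c(N)nc2n1` gives < 1000 nM, which is a limit of the assay and not a number. Compound 3 `CC(C)(C)c1nc(-c2ncc[nH]2)c2c(N)c(C#N)c(N)nc2n1` gives < 1000 nM, also a limit and not a number. Compound 3 therefore has no exact position and stands at the limit of < 1000 nM in this assay, at which 2 of the 3 values shown sit.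

Compound 4 `Cc1c[nH]c(-c2nc(C(C)(C)C)nc3nc(N)c(C#N)c(N)c23)n1` changes 1H-imidazol-2-yl to 4-methyl-1H-imidazol-2-yl, with methyl in place of hydrogen on an aromatic carbon.

The measured steps bear on this only indirectly, since each exchanges the whole group on the aromatic carbon of the shared core. Cyclopentyl in place of butyl gives an at least 6.0-fold lower number from compound 1 to compound 2 (0.77 log units; beyond the scatter), and 1H-imidazol-2-yl in place of butyl gives an at least 6.0-fold lower number from compound 1 to compound 3 (0.77 log units; beyond the scatter). Both are beyond the scatter. The exchange of cyclopentyl for 1H-imidazol-2-yl gives a step that the two limits leave unreadable from compound 2 to compound 3, so it offers no size to carry over. For the measured compounds named here, no measured step adds a methyl to the 1H-imidazol-2-yl group, so no step beyond the scatter is expected in this assay, and no direction is favoured.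

The expectation is anchored on compound 3, whose limit is < 1000 nM. The expected step is a step that the limit leaves unreadable from compound 3 to compound 4. Compound 4 is estimated at 600 nM, with an expected range from 200 nM to 1500 nM.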

Compound 4, solubility: 5000 nM
Compound 4: the middle estimate sits 8.3-fold (0.92 log units) below what was measured; measured number above the stated range.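

In this assay, methyl in place of hydrogen on an aromatic carbon of the five-membered aromatic ring gives an at least 5.0-fold higher number from compound 3 to compound 4 (0.69 log units; beyond the scatter), so a change of one heavy atom at this position is enough to lift the number clear of the assay limit. 4-Methyl-1H-imidazol-2-yl in place of cyclopentyl gives an at least 5.0-fold higher number from compound 2 to compound 4 (0.69 log units; beyond the scatter), which shows that a ring group on this carbon of the shared core need not sit at the limit, as the earlier ring compounds did. 4-Methyl-1H-imidazol-2-yl in place of butyl gives a 1.2-fold lower number from compound 1 to compound 4 (0.08 log units; within the scatter), so with this one methyl a ring group reads level with the butyl chain in this assay.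

On these data alone, compound 3 gives < 1000 nM, which is a limit and not a number, so the true size of the methyl step stays open: the limit of < 1000 nM in this assay, at which 2 of the 4 values shown sit. Whether an ethyl group, a methoxy group or an amine in the place of this methyl would read the same way also stays open, as does whether the step would carry over to a group other than 1H-imidazol-2-yl.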